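Chain Extension from Compound 3 to Compound 4

The source may report more compounds than this note shows. Statements on the series, on what has been measured and on what is new or still open speak of the compounds shown alone.

In a functional assay on A549 cells (Homo sapiens) for antiproliferative activity, read by MTT assay, with a stated time of 48 h (on this read-out higher numbers stand for weaker inhibition and lower numbers for stronger inhibition), compound 3 `CN(C)CCn1c(N)c(-c2nc3cc(Cl)ccc3[nH]2)c2nc(C#N)c(C#N)nc21` gives > 50000 nM, which is a limit of the assay and not a number. Compound 4 `CN(C)CCCn1c(N)c(-c2nc3cc(Cl)ccc3[nH]2)c2nc(C#N)c(C#N)nc21` differs from compound 3 by (dimethylamino)methyl in place of dimethylamino on a saturated chain carbon, two bonds along the chain from an aromatic nitrogen. This turns 2-(dimethylamino)ethyl into 3-(dimethylamino)propyl.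

Among the measured compounds shown here, no measured pair isolates this chain change. The nearest evidence comes from two compounds that already carry 3-(dimethylamino)propyl but have other groups on the aromatic carbon: compound 1 `CN(C)CCCn1c(N)c(-c2nc3ccccc3s2)c2nc(C#N)c(C#N)nc21` gives 8870 nM and compound 2 `CN(C)CCCn1c(N)c(-c2nc3ccccc3n2C)c2nc(C#N)c(C#N)nc21` gives 11700 nM. Between them, a 1.3-fold higher number from compound 1 to compound 2 (0.12 log units; within the scatter), so that one exchange of aromatic group made no difference beyond the scatter.

In this assay a step towards a lower number, meaning stronger inhibition, is therefore expected, though its size is poorly defined. The estimated step is an at least 3.3-fold lower number from compound 3 to compound 4 (0.52 log units; beyond the scatter). Compound 4 is expected at 15000 nM, with an estimated range of 5000 nM to 50000 nM.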

Compound 4, half-maximal inhibitory concentration: > 50000 nM
Compound 4: no number, only a limit (the forecaster's own chance of this, stated with the estimate: 20%); at least 3.3-fold (0.52 log units) between middle value and limit.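

With 3-(dimethylamino)propyl held constant, the aromatic group now has a readable effect in this assay: an at least 4.2-fold higher number from compound 2 to compound 4 (0.63 log units; beyond the scatter) and an at least 5.6-fold higher number from compound 1 to compound 4 (0.75 log units; beyond the scatter), whereas the exchange between the two earlier groups gave a 1.3-fold higher number from compound 1 to compound 2 (0.12 log units; within the scatter). 3-(Dimethylamino)propyl alone therefore does not bring compound 4 to a measurable value when 5-chloro-1H-benzimidazol-2-yl is the aromatic group. The effect of the chain change itself cannot be read, because compound 3 and compound 4 both sit at the same assay limit: the limit of > 50000 nM in this assay, at which 2 of the 4 values shown sit.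

Open, on these data alone, is how 2-(dimethylamino)ethyl compares with 3-(dimethylamino)propyl when 1,3-benzothiazol-2-yl or 1-methyl-1H-benzimidazol-2-yl is the aromatic group. Also open, as far as these compounds go, are the contribution of the chlorine, which unsubstituted 1H-benzimidazol-2-yl would address, and the outcome with a longer chain such as 4-(dimethylamino)butyl.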